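This account rests on a few compounds, and the source may have more. Where it says the series, first, only, none or still open, it means among the compounds named here.

Measured in an ADME assay for pharmacokinetics; a higher number here means that the compound lasts longer, a lower number that the compound disappears faster:
Compound 1 `CCCSC1=Nc2ccccc2S(=O)(=O)N1Cc1ccc(-c2ccccc2C(=O)O)cc1` gives >> 24 h
Compound 2 `CCCCC1=NS(=O)(=O)c2ccccc2N1Cc1ccc(-c2ccccc2C(=O)O)cc1` gives >> 24 h

In this assay compound 2 stands at >> 24 h as a limit of the assay, not as a number. Compound 1 likewise gives >> 24 h as a limit. The step to compound 3 `CCCSC1=NS(=O)(=O)c2ccccc2N1Cc1ccc(-c2ccccc2C(=O)O)cc1` puts propylsulfanyl in place of butyl on a carbon with a double bond to nitrogen, between two ring nitrogen atoms, and propylsulfanyl in place of butyl on a carbon with a double bond to nitrogen is the whole change. Within the data shown here, no step between measured compounds is available to size it. Among the measured compounds shown here, with the limit of >> 24 h in this assay, at which 2 of the 2 values shown sit, as the only guide, and compound 2 among those values, no step beyond the scatter is expected in this assay in either direction. The estimate amounts to a step that the limit leaves unreadable from compound 2 to compound 3 that is expected to stay within the scatter. The estimate for compound 3 is 30 h with an expected range from 15 h to 60 h in this measurement.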

Compound 3, half-life: >> 24 h
Compound 3: a limit, no number (the forecaster's own chance of this, stated with the estimate: 80%); the middle value lies beyond the limit too.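

In this assay compound 3 gives >> 24 h, which is a limit of the assay and not a number. Among these compounds, compound 2 sits at a limit too, so no step from compound 2 to compound 3 can be read. The compounds shown leave open what half-life any of them actually has, and whether propylsulfanyl in place of butyl alters it.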